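Three Weak Cytotoxins and a Diethylamino Variant

The source may hold more compounds than are shown below. What is called first, only, known or untested is meant among the compounds shown, and "the series" means these compounds.

Compound 1, `CCCCNC(=S)N/N=C\c1c[nH]c2ccccc12`: in an ADME assay on KB cells (Homo sapiens) for cytotoxicity, read by MTT assay, with a stated time of 44 h (a higher number here means a weaker inhibitor, a lower number a stronger inhibitor), compound 1 gives > 100000 nM, which is a limit.
Compound 2, `Fc1cccc(F)c1NC(=S)N/N=C\c1c[nH]c2ccccc12`: here compound 2 gives > 100000 nM, which is a limit.
Compound 3, `CN(Cc1ccccc1)C(=S)N/N=C\c1c[nH]c2ccccc12`: here compound 3 gives > 100000 nM, which is a limit.

For the measured compounds named here, none of the three compounds shows a measurable number in this assay; each result is only a limit, so no ranking among them is possible and no step between any pair can be sized. Compound 1 therefore stands at the same point as the other two, at the limit of > 100000 nM in this assay, at which 3 of the 3 values shown sit. The shared core of compound 1 carries a thiocarbonyl group, and the only part that varies across the three compounds is the group on that thiocarbonyl carbon.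

Compound 4, `CCN(CC)C(=S)N/N=C\c1c[nH]c2ccccc12`, has not yet been tested in this assay. It differs from compound 1 by diethylamino in place of butylamino on a thiocarbonyl carbon. Since every measured compound sits at the limit, no direction or size can be read from the data for such a change, and the step from compound 1 to compound 4 is expected to be none beyond the scatter, as a step that the limit leaves unreadable from compound 1 to compound 4 states.

For compound 4 the expected result in this assay is 150000 nM, with a range from 50000 nM to 500000 nM, most likely reported as a limit.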

Compound 4, half-maximal inhibitory concentration: > 100000 nM
Compound 4: no number, only a limit (the forecaster's own chance of this, stated with the estimate: 85%); the middle value is on the limit's open side.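

No step can be read from compound 1 to compound 4, because each result is only a limit and not a number: the limit of > 100000 nM in this assay, at which 4 of the 4 values shown sit.

The compounds shown leave open whether any group on the thiocarbonyl carbon of the shared core could give a measurable number in this assay.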